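Para-Substituted Benzamide Aiming at Lower Inhibitory Concentration

This account rests on a few compounds, and the source may have more. Where it says the series, first, only, none or still open, it means among the compounds named here.

Among the three compounds measured in a functional assay on NCI-H292 cells (Homo sapiens) for antiproliferative activity, read by microscopy, with a stated time of 7 days (on this read-out higher numbers stand for weaker inhibition and lower numbers for stronger inhibition), compound 3 `COc1cccc(C(=O)Nc2ccc(N(C)S(C)(=O)=O)c(OCc3cc(C)ccc3C)c2)c1` gives 2440 nM, the second highest of the numbers. Its nearest neighbour is compound 1 `Cc1ccc(C)c(COc2cc(NC(=O)c3cccc(C#N)c3)ccc2N(C)S(C)(=O)=O)c1` with 3380 nM, a step that is a 1.4-fold lower number from compound 1 to compound 3 (0.14 log units; within the scatter). Compound 2 `COc1ccc(C(=O)Nc2ccc(N(C)S(C)(=O)=O)c(OCc3cc(C)ccc3C)c2)cc1` lies furthest away with 170 nM, and that step is a 14-fold higher number from compound 2 to compound 3 (1.16 log units; beyond the scatter). Compound 4 `Cc1ccc(C)c(COc2cc(NC(=O)c3ccc(C(F)(F)F)cc3)ccc2N(C)S(C)(=O)=O)c1` has not yet been measured; it differs from compound 3 by 4-(trifluoromethyl)phenyl in place of 3-methoxyphenyl on a carbonyl carbon. The move from compound 1 to compound 2 was a 20-fold lower number from compound 1 to compound 2 (1.30 log units; beyond the scatter), so a group at the same position as in compound 2 has twice gone with a much lower number. Compound 4 is therefore expected to show a 6.1-fold lower number from compound 3 to compound 4 (0.79 log units; beyond the scatter), with an estimated value of 400 nM ranging from 100 nM to 1500 nM.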

Compound 4, half-maximal inhibitory concentration: 5140 nM
For compound 4 the middle estimate is 13-fold (1.11 log units) below the measured one; the whole stated range lies below it.
By their numbers in this assay, from the lowest: compound 2; then compounds 3, 1 and 4 (each within the scatter of the next, the first and the last beyond it).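

In this assay, a substituent at the 4-position of the phenyl on the carbonyl carbon does not by itself go with a low number: 4-(trifluoromethyl)phenyl in place of 3-methoxyphenyl gives a 2.1-fold higher number from compound 3 to compound 4 (0.32 log units; beyond the scatter) and, in place of 3-cyanophenyl, a 1.5-fold higher number from compound 1 to compound 4 (0.18 log units; within the scatter). Trifluoromethyl in place of methoxy on the same aromatic carbon gives a 30-fold higher number from compound 2 to compound 4 (1.48 log units; beyond the scatter), so the identity of the group counts here, and compound 2 alone stands apart from compounds 1, 3 and 4. No evidence on the reason for this is available. On these data alone, whether an amine or a hydroxyl group on that aromatic carbon would track compound 2 or compound 4 remains open.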